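This account rests on a few compounds, and the source may have more. Where it says the series, first, only, none or still open, it means among the compounds named here.

Compound 1 `CNC(=O)c1cc(Oc2ccc3nc(Nc4cccc(Cl)c4)ncc3c2)ccn1` gives in a physicochemical assay for solubility, at pH 7; a higher number here means a more soluble compound, a lower number a less soluble compound < 1000 nM, which is a limit of the assay and not a number.
Compound 2 `CNC(=O)c1cc(Oc2ccc3nc(Nc4ccc(C(F)(F)F)cc4)ncc3c2)ccn1` gives in this assay < 1000 nM, likewise a limit of the assay.

Compound 2 therefore stands only at a limit in this assay, where (the limit of < 1000 nM in this assay, at which 2 of the 2 values shown sit). Within the data shown here, the single measured step, a step that the two limits leave unreadable from compound 1 to compound 2, has no readable size. Compound 3 `CNC(=O)c1cc(Oc2ccc3nc(Nc4ccc(C(C)C)cc4)ncc3c2)ccn1` differs from compound 2 by isopropyl in place of trifluoromethyl on an aromatic carbon. Among the measured compounds shown here, no measured step shows how such a change moves this assay, so no direction beyond the scatter can be expected, and compound 3 is expected to sit at the limit again. The step this estimate means is expected to be a step that the limit leaves unreadable from compound 2 to compound 3. Compound 3 is estimated at 500 nM, between 100 nM and 2000 nM.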

Compound 3, solubility: < 1000 nM
Compound 3: a limit, no number (the forecaster's own chance of this, stated with the estimate: 70%); the middle value is on the limit's open side.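

Compound 1, compound 2 and compound 3 all sit at a limit in this assay, so no step among them can be read: the limit of < 1000 nM in this assay, at which 3 of the 3 values shown sit.

As far as these compounds go, how far apart the three compounds really lie, and in which direction isopropyl in place of trifluoromethyl moves the solubility, stays open.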